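The source may hold more compounds than are shown below. What is called first, only, known or untested is meant among the compounds shown, and "the series" means these compounds.

Compound 1, `Cc1nn(-c2ncnc3nc[nH]c23)c2c1C(OCc1ccccc1F)CC(=O)N2`, carries a 2-fluorophenyl group on a saturated chain carbon bound to an oxygen on a saturated carbon. In a functional assay on HEK293 cells for agonist activity at G-protein coupled receptor 39 (Homo sapiens), read by scintillation proximity assay and inositol phosphate accumulation, with a stated time of 75 min, in the presence of a further agent that is not named here (a higher number here means that more compound is needed for the effect, a lower number that less compound is needed), compound 1 gives 4 nM. Compound 2, `CCCCCCCCOC1CC(=O)Nc2c1c(C)nn2-c1ncnc2nc[nH]c12`, has a heptyl chain at that same place, and in this assay compound 2 gives 8 nM. Among the compounds with values here, the one measured step, a 2.0-fold higher number from compound 1 to compound 2 (0.30 log units; within the scatter), shows that swapping an aromatic ring for a straight chain at this position left the result inside the ordinary scatter; the two numbers cannot be told apart, so compound 2 stands level with compound 1 rather than apart from it.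

Compound 3, `Cc1nn(-c2ncnc3nc[nH]c23)c2c1C(OCc1ccc(C#N)cc1)CC(=O)N2`, returns an aromatic ring to this position: 4-cyanophenyl in place of heptyl on a saturated chain carbon bound to an oxygen on a saturated carbon. The step from compound 1 to compound 2 is the only one that bears on it, since it moved between a phenyl ring and an alkyl chain at exactly this place and stayed within the scatter. A change of similar size, or none beyond the scatter, is therefore expected in this assay, leaning toward a somewhat lower number because a 2.0-fold higher number from compound 1 to compound 2 (0.30 log units; within the scatter) ran the other way. Compound 3 is expected to give 5 nM, with a range from 1.5 nM to 17 nM. This expectation amounts to a step of a 1.6-fold lower number from compound 2 to compound 3 (0.20 log units; within the scatter).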

Compound 3, half-maximal effective concentration: 4 nM
For compound 3 the middle estimate is 1.3-fold (0.10 log units) above the measured one; the range from low to high includes it.
By their numbers in this assay, from the lowest: compounds 1, 3 and 2 (each within the scatter of the next).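

Set against the heptyl chain in this assay, the 4-cyanophenyl group gives a 2.0-fold lower number from compound 2 to compound 3 (0.30 log units; within the scatter), and set against the 2-fluorophenyl group it gives no change at the digits printed from compound 1 to compound 3 (within the scatter). This adds a third kind of group to the comparison: a ring carrying a nitrile now stands with a ring carrying fluorine and a straight chain, and on a saturated chain carbon bound to an oxygen on a saturated carbon, the three compounds cannot be told apart in this read-out, so the earlier result no longer rests on a single pair. No available measurement accounts for why such different groups read alike.

The compounds shown leave open how far this tolerance extends, since all three groups carry no net charge, and an amine or a carboxylic acid at this same place could read differently, as could a chain much shorter than heptyl, such as methyl or ethyl. They also leave open whether a ring bearing a nitrile at another place, or a change elsewhere on the shared core, would separate compounds that this position does not.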